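The compounds below may be only part of what the source reports. "The series", "measured", "known", "first", "only" and "open" are said of these compounds alone.

Measured in a functional assay on Caco-2 cells (Homo sapiens), read by MTT assay, with a stated time of 48 h; a lower number here means a stronger inhibitor, a higher number a weaker inhibitor:
- compound 1 `CCN(CC)CCNC(=O)c1ccc(C(CC)(CC)c2ccc(OCC(=O)C(C)(C)C)c(C)c2)n1CC`: 1600 nM
- compound 2 `CCn1c(C(=O)NCCN(C)C)ccc1C(CC)(CC)c1ccc(OCC(=O)C(C)(C)C)c(C)c1`: 1600 nM
- compound 3 `CCN(CC)CCCNC(=O)c1ccc(C(CC)(CC)c2ccc(OCC(=O)C(C)(C)C)c(C)c2)n1CC`: 1000 nM

Compound 3 at 1000 nM is not separated from the other two, since the steps of a 1.6-fold lower number from compound 1 to compound 3 (0.20 log units; within the scatter) and a 1.6-fold lower number from compound 2 to compound 3 (0.20 log units; within the scatter) both lie within the scatter. The next entry is compound 4 `CCn1c(C(=O)NCCN)ccc1C(CC)(CC)c1ccc(OCC(=O)C(C)(C)C)c(C)c1` with the change amino in place of (diethylamino)methyl on a saturated chain carbon, two bonds along the chain from an amide-type nitrogen in words: amino in place of (diethylamino)methyl on a saturated chain carbon, two bonds along the chain from an amide-type nitrogen.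

The step of no change at the digits printed from compound 1 to compound 2 (within the scatter) also bears on this change, and it too lies within the scatter. All three measured steps alter the same chain end, but none ends in the amino group, so the change remains an extrapolation. The expected step is a 1.6-fold higher number from compound 3 to compound 4 (0.20 log units; within the scatter) in this assay and is not expected to exceed the scatter. Compound 4 is estimated at 1600 nM with an expected range from 500 nM to 5000 nM given this thin evidence.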

Compound 4, half-maximal inhibitory concentration: 1900 nM
For compound 4 the middle estimate is 1.2-fold (0.07 log units) below the measured one; measured number inside the range.
By their numbers in this assay, from the lowest: compounds 3, 1, 2 and 4 (each within the scatter of the next).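

In this assay the chain end now reaches the unsubstituted amino group, and the three new steps are a 1.9-fold higher number from compound 3 to compound 4 (0.28 log units; within the scatter) and a 1.2-fold higher number from compound 2 to compound 4 (0.07 log units; within the scatter) and a 1.2-fold higher number from compound 1 to compound 4 (0.07 log units; within the scatter) in turn. Neither the loss of the ethyl or methyl groups on the chain-end nitrogen nor the shorter chain of compound 4 relative to compound 3 separates these compounds, so this position has so far tolerated every change shown, from amino to (diethylamino)methyl, without a step beyond the scatter. No measurement is available that would explain this flat result.

From the compounds shown here alone, whether a longer chain than 3-(diethylamino)propyl, a morpholine at the chain end or a carboxylic acid in place of the amine would move the number beyond the scatter stays open. Equally open, going by these compounds, is whether an ester in place of the amide would separate from these four compounds.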